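Swapping methoxy for prop-1-en-1-yl on a carbonyl carbon

The source may hold more compounds than are shown below. What is called first, only, known or untested is meant among the compounds shown, and "the series" means these compounds.

In a functional assay on PANC-1 cells (Homo sapiens) for cytotoxicity, read by MTT assay, with a stated time of 24 h (a higher number here means a weaker inhibitor, a lower number a stronger inhibitor), compound 1 (`O=C1C=CCC(/C=C/c2ccccc2)N1`) gives > 100000 nM as a limit of the assay and not as a number. Among the measured compounds shown here, compound 2 (`COC(=O)N1C(=O)C=CCC1/C=C/c1ccccc1`) gives 53700 nM as the only actual number so far. Compound 3 (`C/C=C/C(=O)N1C(=O)C=CCC1/C=C/c1ccccc1`) carries prop-1-en-1-yl in place of methoxy on a carbonyl carbon. For the measured compounds named here, the one measured step that bears on this (an at least 1.8-fold lower number from compound 1 to compound 2 (0.27 log units; that floor lies within the scatter)) put methoxycarbonyl in place of hydrogen on an amide-type nitrogen in a ring, and it offers only a floor that stays within the scatter. Going by the values given here, no measurement yet tests a change on this carbonyl carbon. Anchored on compound 2 at 53700 nM the step expected in this assay is none beyond the scatter. The estimate means an expected small step (a 1.3-fold lower number from compound 2 to compound 3 (0.13 log units; within the scatter)) with wide uncertainty. Compound 3 is estimated at 40000 nM with an expected range from 10000 nM to 100000 nM for now.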

Compound 3, half-maximal inhibitory concentration: 4200 nM
The estimate for compound 3 lay 9.5-fold (0.98 log units) above the measured number; measured number below the stated range.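

In this assay, among the compounds shown here, the group on this carbonyl carbon clearly matters: prop-1-en-1-yl in place of methoxy gives a 13-fold lower number from compound 2 to compound 3 (1.11 log units; beyond the scatter), the first change here to reach beyond the scatter. Measured against the bare amide, (prop-1-en-1-yl)carbonyl in place of hydrogen on the amide-type nitrogen in a ring gives an at least 23-fold lower number from compound 1 to compound 3 (1.37 log units; beyond the scatter), whereas methoxycarbonyl there offered only a floor within the scatter. Compound 1 stands at a limit of the assay and not at a number, so this larger step is also only a floor: the limit of > 100000 nM in this assay, at which 1 of the 3 values shown sits.

The compounds shown leave open whether the double bond of prop-1-en-1-yl is needed, which a saturated propyl chain, a longer chain or an amine on this carbonyl carbon could test. They also do not show why the number falls.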